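The source may hold more compounds than are shown below. What is called first, only, known or untested is meant among the compounds shown, and "the series" means these compounds.

Working notes on the chalcone-like series built on the shared core.

For the measured compounds named here, compound 1 `COc1ccc(/C=C/C(=O)c2ccc(OC)c3c2OC(C)(C)C=C3)c(F)c1` is the one member with a measured number. In a functional assay on HepG2 cells (Homo sapiens) for antiproliferative activity, read by MTT assay, with a stated time of 24 h (a lower number here means a stronger inhibitor, a higher number a weaker inhibitor), compound 1 gives 7560 nM. The second member, compound 2 `COc1ccc(C(=O)/C=C/c2ccc(N(c3ccccc3)c3ccccc3)cc2)c2c1C=CC(C)(C)O2`, is reported only as a limit: in this assay compound 2 gives > 10000 nM, which is the assay limit and not a number. Within the pair, compound 1 therefore stands as the only defined value, the other sitting at the limit of > 10000 nM in this assay, at which 1 of the 2 values shown sits.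

Compound 3 `COc1ccc(C(=O)/C=C/c2cccc(O)c2)c2c1C=CC(C)(C)O2` has not yet been run in this assay. It differs from compound 1 by 3-hydroxyphenyl in place of 2-fluoro-4-methoxyphenyl on a double-bonded chain carbon bound to a double-bonded chain carbon. Going by the values given here, no measured step between two neighbours exists here, so the size of this change in this assay is open. The expectation is a modest step, if any, toward a lower number for compound 3 relative to compound 1, but one that may well sit inside the ordinary scatter.

On that basis compound 3 is estimated at 5500 nM in this assay, with a range from 2200 nM to 14000 nM, corresponding to an expected step of a 1.4-fold lower number from compound 1 to compound 3 (0.14 log units; within the scatter).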

Compound 3, half-maximal inhibitory concentration: > 10000 nM
Compound 3: only a limit was reported; the forecaster's own chance of this, stated with the estimate: 25%; middle value at least 1.8-fold (0.25 log units) away from the limit.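

In this assay compound 3 gives > 10000 nM, which is a limit of the assay and not a number. Placing 3-hydroxyphenyl in place of 2-fluoro-4-methoxyphenyl on a double-bonded chain carbon bound to a double-bonded chain carbon gives the first readable step in the series, an at least 1.3-fold higher number from compound 1 to compound 3 (0.12 log units; that floor lies within the scatter), so this change brings no measurable gain in antiproliferative activity, although its true size remains unknown. For the compounds shown here, the series now gathers at the ceiling of the read-out, leaving the value of compound 1 as the only defined number: the limit of > 10000 nM in this assay, at which 2 of the 3 values shown sit.

The compounds shown leave open whether any replacement at this position can give a lower number than compound 1, and with a limit on one side of the only step, they cannot separate the loss of the fluorine from the loss of the methoxy group or the arrival of the hydroxyl. A phenyl ring carrying an amine or a carboxylic acid at this position would test whether the position tolerates anything beyond the aryl groups shown here.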